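Methoxy for fluoro on the compound 3 scaffold

The source may report more compounds than this note shows. Statements on the series, on what has been measured and on what is new or still open speak of the compounds shown alone.

Three compounds of the series carry a number in a functional assay on CHO cells for agonist activity at Alpha-2C adrenergic receptor (Homo sapiens); on this read-out higher numbers stand for larger maximal responses and lower numbers for smaller maximal responses. Compound 1 `COc1ccc(S(C)(=O)=O)c(NCC2=NCCN2)c1` gives 49%. Compound 2 `CSc1ccc(C)cc1NCC1=NCCN1` gives 81%. Compound 3 `CSc1ccc(F)cc1NCC1=NCCN1` gives 97%, the highest of the three; its nearest neighbour is compound 2, and compound 1 lies furthest from it. Going by the values given here, the one step measured, a number 16 percentage points higher from compound 2 to compound 3 (beyond the scatter), concerns fluoro in place of methyl on an aromatic carbon and is of modest size.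

Compound 4 `COc1ccc(SC)c(NCC2=NCCN2)c1` differs from compound 3 by methoxy in place of fluoro on an aromatic carbon. Among the compounds with values here, no measured step involves a methoxy group; the only step available, from compound 2 to compound 3, shows that exchanging the group at this aromatic carbon moves the maximum by a modest amount. Compound 1, which also carries methoxy but differs from compound 4 elsewhere, sits low, so the direction cannot be read from it alone. The step to compound 4 is therefore expected to be a modest decrease, a number 19 percentage points lower from compound 3 to compound 4 (beyond the scatter). Compound 4 is expected to give about 78% in this assay, within 55% to 98%.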

Compound 4, largest response reached (reported as maximum), in percent of the reference or control that the assay uses: 74%
Estimate against measurement, compound 4: 4 percentage points above, within the range that was stated.
By their numbers in this assay, from the lowest: compound 1; then compounds 4 and 2 (each within the scatter of the next); then compound 3.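

Para to a methylsulfanyl group, methoxy in place of fluoro gives a number 23 percentage points lower from compound 3 to compound 4 (beyond the scatter) in this assay while methoxy in place of methyl gives a number 7 percentage points lower from compound 2 to compound 4 (within the scatter) at the same carbon, so among these three groups only fluoro separates from the others on this read-out. With methoxy held constant, methylsulfanyl in place of methylsulfonyl gives a number 25 percentage points higher from compound 1 to compound 4 (beyond the scatter) on the same read-out, which shows that the low maximum of compound 1 goes with the methylsulfonyl group and not with methoxy. Nothing available bears on the cause of these steps.

Open, going by these compounds, is whether an amine or a longer chain such as ethoxy at this aromatic carbon would stay level with methoxy and methyl or reach the level of fluoro. Also open, on these data alone, is whether fluoro keeps its place with methylsulfonyl on the core.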